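The source may report more compounds than this note shows. Statements on the series, on what has been measured and on what is new or still open speak of the compounds shown alone.

Three compounds with a shared core differ only in the group on a saturated chain carbon bound to two aromatic carbons. In a functional assay on MCF7 cells (Homo sapiens) for inhibition, read by MTT assay, with a stated time of 48 h (on this read-out higher numbers stand for weaker inhibition and lower numbers for stronger inhibition), compound 1 (`Brc1ccc2[nH]cc(C(c3ccccc3)c3c[nH]c4ccc(Br)cc34)c2c1`), bearing phenyl, gives 5500 nM. Compound 2 (`Brc1ccc2[nH]cc(C(c3c[nH]c4ccc(Br)cc34)C3CCCCC3)c2c1`), bearing cyclohexyl, gives 4100 nM, and compound 3 (`Brc1ccc2[nH]cc(C(c3ccc4ccccc4c3)c3c[nH]c4ccc(Br)cc34)c2c1`), bearing naphthalen-2-yl, gives 7100 nM. Compound 3 therefore stands within the scatter of both other compounds, and the three values show no order.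

The next compound, compound 4 (`CCCC(c1c[nH]c2ccc(Br)cc12)c1c[nH]c2ccc(Br)cc12`), carries propyl in place of naphthalen-2-yl on that same carbon: propyl in place of naphthalen-2-yl on a saturated chain carbon bound to two aromatic carbons. Within the data shown here, three measured steps bear on this change, since each exchanges the group at this place. They are a 1.3-fold higher number from compound 1 to compound 3 (0.11 log units; within the scatter), a 1.3-fold lower number from compound 1 to compound 2 (0.13 log units; within the scatter) and a 1.7-fold higher number from compound 2 to compound 3 (0.24 log units; within the scatter). All three stay within the scatter, whether the group is exchanged for a larger aromatic one or for a saturated ring. Among the measured compounds shown here, none of the measured compounds has an open chain at this place, however, so the step to propyl goes beyond what has been tested and the range must stay wide. The expected change is therefore none beyond the scatter, and the estimated step is a 1.3-fold lower number from compound 3 to compound 4 (0.11 log units; within the scatter). In this assay, compound 4 is expected at 5500 nM, with an estimated range of 2500 nM to 12000 nM.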

Compound 4, half-maximal inhibitory concentration: 3600 nM
Beside the measured number, compound 4's estimate is 1.5-fold (0.18 log units) above it, and the stated range covers the measured number.
By their numbers in this assay, from the lowest: compounds 4, 2, 1 and 3 (each within the scatter of the next).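

Compound 4 puts the first open chain on a saturated chain carbon bound to two aromatic carbons, and in this assay the exchange of naphthalen-2-yl, with 10 heavy atoms and 2 six-membered aromatic rings, for propyl, with 3 heavy atoms and no ring, gives a 2.0-fold lower number from compound 3 to compound 4 (0.29 log units; within the scatter) and so leaves the number within the scatter despite the largest change in size tested at this place. The exchanges of the two other groups for propyl read the same way, with a 1.1-fold lower number from compound 2 to compound 4 (0.06 log units; within the scatter) and a 1.5-fold lower number from compound 1 to compound 4 (0.18 log units; within the scatter) showing that, among these four compounds, neither an aromatic ring nor any ring on this carbon is needed to keep the number where it stands. Nothing on hand accounts for why this place accepts all four groups alike.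

From the compounds shown here alone, it stays open whether an amine, a carboxylic acid or a chain longer than propyl on this carbon would carry the number beyond the scatter. All four compounds also keep the rest of the shared core unchanged, so they say nothing about replacing its bromine with chlorine or hydrogen.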